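This account rests on a few compounds, and the source may have more. Where it says the series, first, only, none or still open, it means among the compounds named here.

Working notes on the series. Of the compounds shown here, three have been measured in a functional assay on U-87MG ATCC cells for antiproliferative activity against U-87 MG (Homo sapiens), read by MTT assay, with a stated time of 48 h, tested at 5 uM; on this read-out higher numbers stand for a weaker effect at the one concentration tested and lower numbers for a stronger effect. Compound 3 `COc1ccc(-c2nc(SCC(=O)c3sc(-c4ccccc4)nc3C)[nH]c(=O)c2C#N)cc1OC` gives 80.8% in this assay. Compound 1 `COc1ccc(-c2nc(C)c(C(=O)CSc3nc(-c4ccc(OC)c(OC)c4)c(C#N)c(=O)[nH]3)s2)cc1` differs from compound 3 by methoxy in place of hydrogen on an aromatic carbon; in this assay compound 1 gives 81.2%, and the step is a number 0.4 percentage points higher from compound 3 to compound 1 (within the scatter). Compound 2 `Cc1nc(-c2ccccc2)sc1C(=O)CSc1nc(-c2ccc(Cl)c(Cl)c2)c(C#N)c(=O)[nH]1` carries the other core; how the two cores differ is 3,4-dichlorophenyl in place of 3,4-dimethoxyphenyl on an aromatic carbon. In this assay compound 2 gives 98.6%, which stands highest of the three numbers, and the step is a number 17.8 percentage points lower from compound 2 to compound 3 (beyond the scatter). No step is recorded between compound 1 and compound 2; their two values simply lie apart by the amounts already shown against compound 3.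

Compound 4 `COc1ccc(-c2nc(C)c(C(=O)CSc3nc(-c4ccc(Cl)c(Cl)c4)c(C#N)c(=O)[nH]3)s2)cc1` has not yet been measured in this assay. It differs from compound 2 by methoxy in place of hydrogen on an aromatic carbon. Within the data shown here, this is the same change as the one from compound 3 to compound 1, and the place is described in the same words for both pairs, so the change counts as the same, now made on the core of compound 2 rather than on the core of compound 3. The earlier instance left the number where it was, within the scatter. The step from compound 2 to compound 4 is therefore expected to be small, a number 1.6 percentage points lower from compound 2 to compound 4 (within the scatter), resting on the measured step of a number 0.4 percentage points higher from compound 3 to compound 1 (within the scatter). Compound 4 is accordingly estimated at 97% in this assay, with an expected range from 86% to 105%.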

Compound 4, a percentage reported as activity, at one concentration (the size of the read-out at that concentration, not a potency): 101%
Compound 4: the middle estimate sits 4 percentage points below what was measured; measured number inside the range.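

In this assay, among these compounds, the change from phenyl to 4-methoxyphenyl, now made on the core of compound 2, gives a number 2.4 percentage points higher from compound 2 to compound 4 (within the scatter), and it carries over from the core of compound 3 without a detectable difference: the same change on two cores in this assay, a number 0.4 percentage points higher (within the scatter) from compound 3 to compound 1 and a number 2.4 percentage points higher (within the scatter) from compound 2 to compound 4, 2 percentage points apart, within the scatter of two such steps The exchange of 3,4-dimethoxyphenyl for 3,4-dichlorophenyl also carries over, now on the 4-methoxyphenyl compounds, where it gives a number 19.8 percentage points higher from compound 1 to compound 4 (beyond the scatter), and its size matches that of the earlier instance: the same change on two cores in this assay, a number 17.8 percentage points lower (beyond the scatter) from compound 2 to compound 3 and a number 19.8 percentage points lower (beyond the scatter) from compound 4 to compound 1, 2 percentage points apart, within the scatter of two such steps Within these four compounds, each change therefore has much the same effect whichever form of the other position it is made on, but this rests on only one pair of steps per change, at a single concentration in a single cell line, so it shows neither a general rule for the series nor anything about potency.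

Open, going by these compounds, is whether a group other than methoxy in that same place on the phenyl, such as an amine or a carboxylic acid, would also carry from one core to the other. Also open, on these data alone, is whether a step of clearly larger size at this position would transfer as closely as the methoxy step, which stays within the scatter on both cores.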